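Methylamino to isopropylamino: expectation for compound 4

The source may report more compounds than this note shows. Statements on the series, on what has been measured and on what is new or still open speak of the compounds shown alone.

In a functional assay on HCT-116 cells (Homo sapiens) for inhibition, with a stated time of 72 h (on this read-out lower numbers stand for stronger inhibition and higher numbers for weaker inhibition), compound 1 `O=S(=O)(Nc1cccc2c(Cl)c[nH]c12)c1cccnc1` gives 260 nM, compound 2 `Cc1cncc(S(=O)(=O)Nc2cccc3c(C#N)c[nH]c23)c1` gives 190 nM, and compound 3 `CNc1ccc(S(=O)(=O)Nc2cccc3c(Cl)c[nH]c23)cn1` gives 860 nM, the highest of the three numbers. Compound 4 `CC(C)Nc1ccc(S(=O)(=O)Nc2cccc3c(Cl)c[nH]c23)cn1` differs from compound 3 by one change: isopropyl in place of methyl on a nitrogen on an aromatic ring. Among the compounds with values here, no measured step varies the group on that nitrogen. The nearest evidence is a 3.3-fold higher number from compound 1 to compound 3 (0.52 log units; beyond the scatter), a modest step beyond the scatter, with methylamino in place of hydrogen on an aromatic carbon. A small shift toward weaker inhibition is therefore expected, possibly within the scatter: an estimated 1.6-fold higher number from compound 3 to compound 4 (0.21 log units; within the scatter). Compound 4 is estimated at 1400 nM, with an expected range of 500 nM to 3500 nM.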

Compound 4, half-maximal inhibitory concentration: 1300 nM
Compound 4: middle estimate off by 1.1-fold (0.03 log units), on the high side; the range from low to high includes it.
By their numbers in this assay, from the lowest: compounds 2 and 1 (each within the scatter of the next); then compounds 3 and 4 (each within the scatter of the next).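

In this assay, within the data shown here, isopropyl in place of methyl on a nitrogen on an aromatic ring gives a 1.5-fold higher number from compound 3 to compound 4 (0.18 log units; within the scatter) and so gives the first reading at this nitrogen: the larger group does not separate the two compounds. Adding isopropylamino gives a 5.0-fold higher number from compound 1 to compound 4 (0.70 log units; beyond the scatter) and so stays beyond the scatter, as the methylamino step did. No evidence on the cause of either step is available. Still open, from the compounds shown here alone, is whether a longer chain, a cyclopropyl ring or a second methyl on that nitrogen would move the number beyond the scatter.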